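A few compounds are considered here, and "the series" means these few. Any claim that something is new, unique, unknown or untested is made for them only; others in the source may bear on it.

Results in a functional assay on HOS cells (Homo sapiens) for inhibition, with a stated time of 72 h; on this read-out lower numbers stand for stronger inhibition and higher numbers for weaker inhibition:

- Compound 1 `NC1CCC(Nc2nc(NCc3ccc(-c4ccccc4)cc3)c3ncn(C4CCCC4)c3n2)CC1` gives 290 nM
- Compound 2 `NC1CCC(Nc2nc(NCc3ccc(-c4ccco4)cc3)c3ncn(C4CCCC4)c3n2)CC1` gives 102 nM
- Compound 3 `NC1CCC(Nc2nc(NCc3ccc(-c4cccs4)nc3)c3ncn(C4CCCC4)c3n2)CC1` gives 32 nM

Of these three, compound 3 has the lowest number and so the strongest inhibition. Compound 4 `NC1CCC(Nc2nc(NCc3cc(Cl)ccc3O)c3ncn(C4CCCC4)c3n2)CC1` differs from it in one place, on a saturated chain carbon bound to a nitrogen on an aromatic ring, with 5-chloro-2-hydroxyphenyl in place of 6-(thiophen-2-yl)pyridin-3-yl (5-chloro-2-hydroxyphenyl in place of 6-(thiophen-2-yl)pyridin-3-yl on a saturated chain carbon bound to a nitrogen on an aromatic ring). Two modest measured steps changed this same place: a 9.1-fold lower number from compound 1 to compound 3 (0.96 log units; beyond the scatter) and a 3.2-fold lower number from compound 2 to compound 3 (0.50 log units; beyond the scatter). Among the measured compounds shown here, each swapped one two-ring group for another, and no measured compound carries a single-ring group here, so any forecast is uncertain. Compound 3 already sits lowest at 32 nM, so a rise beyond the scatter is expected in this assay, of modest size or somewhat larger. The expected change is a 13-fold higher number from compound 3 to compound 4 (1.10 log units; beyond the scatter). For compound 4 the estimate is 400 nM, with an expected range from 90 nM to 2000 nM.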

Compound 4, half-maximal inhibitory concentration: 490 nM
For compound 4 the middle estimate is 1.2-fold (0.09 log units) below the measured one; low and high end bracket the measured number.
By their numbers in this assay, from the lowest: compound 3; then compound 2; then compounds 1 and 4 (each within the scatter of the next).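

In this assay, a single-ring group now stands at this place, and 5-chloro-2-hydroxyphenyl gives up much of what 6-(thiophen-2-yl)pyridin-3-yl reached (a 15-fold higher number from compound 3 to compound 4 (1.19 log units; beyond the scatter)), and less relative to 4-(furan-2-yl)phenyl (a 4.8-fold higher number from compound 2 to compound 4 (0.68 log units; beyond the scatter)). Against 4-phenylphenyl the step stays within the scatter (a 1.7-fold higher number from compound 1 to compound 4 (0.23 log units; within the scatter)), so two rings alone do not secure a lower number here. No measurement shown explains these steps.

From the compounds shown here alone, the chlorine and the hydroxyl enter together, so what each contributes stays open. Also open, going by these compounds, is how a plain phenyl would compare at this place.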